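A Hydroxy-to-Hydrogen Step Beside the Cytotoxicity Limit

The compounds below may be only part of what the source reports. "The series", "measured", "known", "first", "only" and "open" are said of these compounds alone.

Of the compounds shown here, three of one core have been tested in an ADME assay on DG-75 cells (Homo sapiens) for cytotoxicity, read by MTT assay, with a stated time of 120 h; on this read-out higher numbers stand for weaker inhibition and lower numbers for stronger inhibition. Compound 1 `N#C[C@H]1[C@H](O)[C@@H](CO)O[C@H]1n1cnc2c(N)ncnc21` returns only a limit of this assay, > 15000 nM. Compound 2 `N#C[C@H]1[C@H](O)[C@@H](CO)O[C@H]1n1cnc2c(N)nc(N)nc21` likewise gives a limit, > 15000 nM. Compound 3 `N#C[C@H]1[C@H](O)[C@@H](CO)O[C@H]1n1cnc2c(O)nc(N)nc21` also reaches only a limit, > 15000 nM. The step that the two limits leave unreadable from compound 1 to compound 2 and the step that the two limits leave unreadable from compound 2 to compound 3 are therefore unreadable, and compound 3 stands at that limit alone, since (the limit of > 15000 nM in this assay, at which 3 of the 3 values shown sit). Compound 4 `N#C[C@H]1[C@H](O)[C@@H](CO)O[C@H]1n1cnc2cnc(N)nc21` differs from compound 3 by hydrogen in place of hydroxy on an aromatic carbon. No measured step reads on this change, so its size in this assay cannot be drawn from the numbers shown. Compound 4 is expected to sit at the limit again, estimated at 20000 nM between 8000 nM and 50000 nM. The expected step that the limit leaves unreadable from compound 3 to compound 4 is flat.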

Compound 4, half-maximal inhibitory concentration: > 15000 nM
Compound 4 was reported as a limit (the forecaster's own chance of this, stated with the estimate: 85%); the middle value lies beyond the limit too.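

In this assay compound 4 also gives only a limit, > 15000 nM. No step from compound 2 or compound 3 to compound 4 can be read: the limit of > 15000 nM in this assay, at which 4 of the 4 values shown sit.

The compounds shown leave open whether any of these exchanges on the shared core changes cytotoxicity at all.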